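Fused bicyclic amides in the sulfonyl-benzyl series

A few compounds are considered here, and "the series" means these few. Any claim that something is new, unique, unknown or untested is made for them only; others in the source may bear on it.

Measured:
compound 1 `O=C(NCc1ccc(S(=O)(=O)c2ccccc2)cc1)c1ccc2nccn2c1`, 18 nM
compound 2 `O=C(NCc1ccc(S(=O)(=O)c2ccccc2)cc1)c1c[nH]c2ccncc12`, 1900 nM

Compound 2 gives the highest number of the two in an assay for inhibition of Nicotinamide phosphoribosyltransferase (Homo sapiens), read by mass spectrometry, with stated times of 15 min and 30 min; a lower number here means a stronger inhibitor, a higher number a weaker inhibitor; its nearest neighbour is compound 1, and the gap is a 110-fold higher number from compound 1 to compound 2 (2.02 log units; beyond the scatter). Compound 3 `O=C(NCc1ccc(S(=O)(=O)c2ccccc2)cc1)c1ccc2nncn2c1` is not yet measured. Compound 3 differs from compound 2 by a group of 9 heavy atoms (6 carbon, 3 nitrogen; one five-membered aromatic ring with 3 hetero atoms, one six-membered aromatic ring with 1 hetero atom) in place of a group of 9 heavy atoms (7 carbon, 2 nitrogen; one five-membered aromatic ring with 1 hetero atom, one six-membered aromatic ring with 1 hetero atom), on a carbonyl carbon. The step from compound 1 to compound 2 bears on this, since it also swapped the fused bicyclic group on the carbonyl carbon and was large. Compound 3 returns to a five-membered ring with more than one hetero atom, so a large step down in this assay is expected, a 63-fold lower number from compound 2 to compound 3 (1.80 log units; beyond the scatter). For compound 3 the estimate is 30 nM, within 8 nM to 150 nM.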

Compound 3, half-maximal inhibitory concentration: 370 nM
Compound 3: middle estimate off by 12-fold (1.09 log units), on the low side; the measured number lies above the stated range.
By their numbers in this assay, from the lowest: compound 1; then compound 3; then compound 2.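

In this assay, the hetero atom count of the five-membered aromatic ring does not set the order on its own, as a 5.1-fold lower number from compound 2 to compound 3 (0.71 log units; beyond the scatter) recovers only part of the loss. Even so, a 21-fold higher number from compound 1 to compound 3 (1.31 log units; beyond the scatter) shows that adding a hetero atom to the group of compound 1 does not match it, and the group with 2 hetero atoms in that ring stays lowest. No measurement here accounts for this order. Still open, as far as these compounds go, is whether an amine or a methyl group on the fused group of compound 1 would keep its low number.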